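Moving the ring nitrogen at the sulfur-linked end

The source may report more compounds than this note shows. Statements on the series, on what has been measured and on what is new or still open speak of the compounds shown alone.

Compound 1: `Cc1c(OCCCCOc2ccccc2)ccc(C(=O)CC(C)C)c1O`, 4550 nM
Compound 2: `Cc1c(OCCCCOc2ccccc2F)ccc(C(=O)CC(C)C)c1O`, 1990 nM
Compound 3: `Cc1c(OCCCCSc2cccnc2)ccc(C(=O)CC(C)C)c1O`, 1090 nM

Of the compounds shown here, three with a shared core have been measured in a functional assay for binding affinity to metabotropic glutamate receptor 2 (Homo sapiens), read by GTPgammaS binding; on this read-out higher numbers stand for an effect only at larger amounts of compound and lower numbers for an effect already at smaller amounts. Compound 3 stands lowest of the three numbers; its nearest neighbour is compound 2, with a 1.8-fold lower number from compound 2 to compound 3 (0.26 log units; within the scatter), and the furthest is compound 1, with a 4.2-fold lower number from compound 1 to compound 3 (0.62 log units; beyond the scatter). The remaining step, a 2.3-fold lower number from compound 1 to compound 2 (0.36 log units; beyond the scatter), concerns a change at the aromatic ring on the far end of the chain.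

Compound 4, `Cc1c(OCCCCSc2ccncc2)ccc(C(=O)CC(C)C)c1O`, differs from compound 3 by one change: pyridin-4-yl in place of pyridin-3-yl on a sulfur. Within the data shown here, none of the measured steps tests a shift of the nitrogen within that ring; the two steps that reach the same end of the chain, from compound 1 to compound 3 and from compound 2 to compound 3, replace the whole terminal group rather than reposition an atom within it. Both were modest, and the pair of compounds 2 and 3 fell within the scatter. The expectation for this step in this assay is therefore no movement beyond the scatter, with a 1.1-fold higher number from compound 3 to compound 4 (0.04 log units; within the scatter). Compound 4 is thus estimated at 1200 nM, expected to lie between 450 nM and 3200 nM.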

Compound 4, half-maximal effective concentration: 340 nM
Compound 4: the middle estimate sits 3.5-fold (0.55 log units) above what was measured; measured number outside the range, below it.
By their numbers in this assay, from the lowest: compound 4; then compounds 3 and 2 (each within the scatter of the next); then compound 1.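

In this assay, among these compounds, the earlier steps replaced the whole terminal group, whereas compounds 3 and 4 have the same atoms, joined differently, and pyridin-4-yl in place of pyridin-3-yl on a sulfur gives a 3.2-fold lower number from compound 3 to compound 4 (0.51 log units; beyond the scatter) on its own. Among the compounds shown here, the place of the nitrogen within this ring therefore matters in its own right, which none of the earlier steps could show. For the compounds shown here, the whole-group replacements also now reach further, with a 5.9-fold lower number from compound 2 to compound 4 (0.77 log units; beyond the scatter) and a 13-fold lower number from compound 1 to compound 4 (1.13 log units; beyond the scatter) as the only large step among the four compounds, and nothing available here accounts for the effect of moving the nitrogen.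

The compounds shown leave open how pyridin-2-yl on the same sulfur would compare with pyridin-3-yl and pyridin-4-yl. They also do not separate the contribution of the sulfur from that of the ring nitrogen in the steps from the phenoxy end, a question that (pyridin-4-yl)oxy or phenylsulfanyl on the same saturated chain carbon would address.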